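The source may report more compounds than this note shows. Statements on the series, on what has been measured and on what is new or still open speak of the compounds shown alone.

In an ADME assay on Vero cells (Chlorocebus sabaeus) for cytotoxicity, read by resazurin assay, with a stated time of 3 days (a lower number here means a stronger inhibitor, a higher number a weaker inhibitor), compound 1 `CCN(CC)c1cc2[nH]c(C3CCCCC3)nc2cc1NC(=O)OCCOCCOC` reaches only a limit of the assay, > 100 ug/mL. Compound 2 `CCN(CC)c1cc2[nH]c(C3CCCCC3)nc2cc1NC(=O)OCC(F)(F)F` likewise returns a limit, > 100 ug/mL. Compound 3 `CCN(CC)c1cc2[nH]c(C3CCCCC3)nc2cc1NC(=O)c1cnccn1` also returns a limit, > 100 ug/mL. Compound 3 therefore stands exactly where its two neighbours stand, at the limit of > 100 ug/mL in this assay, at which 3 of the 3 values shown sit. The measured steps a step that the two limits leave unreadable from compound 1 to compound 2, a step that the two limits leave unreadable from compound 1 to compound 3 and a step that the two limits leave unreadable from compound 2 to compound 3 cannot be sized, because of the limit of > 100 ug/mL in this assay, at which 3 of the 3 values shown sit, no numbers exist to compare. Compound 4 `CCCC(C)OC(=O)Nc1cc2nc(C3CCCCC3)[nH]c2cc1N(CC)CC` differs from compound 3 by 1-methylbutoxy in place of pyrazin-2-yl on a carbonyl carbon. Going by the values given here, no measured step points in any direction for this change, so the expected step of a number no higher from compound 3 to compound 4 (the limit leaves the size open) in this assay is none beyond the scatter. Compound 4 is therefore estimated at 100 ug/mL, with a range from 50 ug/mL to 200 ug/mL, most likely again a limit.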

Compound 4, half-maximal inhibitory concentration: > 100 ug/mL
Compound 4 ended at the assay's limit (the forecaster's own chance of this, stated with the estimate: 85%); the middle value sits exactly at the limit.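

No new step can be read between compound 4 and compound 1, compound 2 or compound 3 in this assay, because all four compounds share one assay limit: the limit of > 100 ug/mL in this assay, at which 4 of the 4 values shown sit.

The compounds shown leave open whether any change on the carbonyl carbon shifts the read-out in this assay.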